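From methoxy to nitro: the step to compound 4

The source may hold more compounds than are shown below. What is called first, only, known or untested is meant among the compounds shown, and "the series" means these compounds.

In a functional assay on KB cells (Homo sapiens) for inhibition (on this read-out lower numbers stand for stronger inhibition and higher numbers for weaker inhibition), two numbers and one limit are available so far. Compound 1 `Nc1nc2cc(Cl)c(Cl)cc2n1Cc1ccc([N+](=O)[O-])cc1` gives 35000 nM as its value and compound 3 `COc1ccc(Cn2c(Br)nc3cc(Cl)c(Cl)cc32)cc1` gives 55000 nM as its value. These two numbers lie within the scatter of each other, so neither is placed ahead of the other.

Compound 2 `Clc1cc2nc(Br)n(Cc3ccccc3)c2cc1Cl` reads > 100000 nM and that entry is a limit of the assay, not a number.

Compound 4 `O=[N+]([O-])c1ccc(Cn2c(Br)nc3cc(Cl)c(Cl)cc32)cc1` has nitro in place of methoxy on an aromatic carbon of compound 3, para to a large group (nitro in place of methoxy on an aromatic carbon). Among the measured compounds shown here, one measured step touches this carbon: an at least 1.8-fold lower number from compound 2 to compound 3 (0.25 log units; that floor lies within the scatter) when methoxy replaces hydrogen. That step starts from a limit and its floor stays within the scatter, so it fixes no firm size for a change here. Compound 1, which also carries nitro, stands at 35000 nM and so offers no reason to expect a large move.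

No step beyond the scatter is therefore expected in this assay for this exchange. The expected step is a 1.1-fold lower number from compound 3 to compound 4 (0.04 log units; within the scatter) as the working estimate. For compound 4 the estimated value is 50000 nM with an expected range from 20000 nM to 100000 nM and a reading at the limit of the assay remains possible.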

Compound 4, half-maximal inhibitory concentration: 40000 nM
Compound 4: the middle estimate sits 1.3-fold (0.10 log units) above what was measured; the measured number falls inside the stated range.
By their numbers in this assay, from the lowest: compounds 1, 4 and 3 (each within the scatter of the next). At a limit, above all of these: compound 2.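

In this assay, the exchange of methoxy for nitro on the aromatic carbon para to a large group gives a 1.4-fold lower number from compound 3 to compound 4 (0.14 log units; within the scatter), so this read-out does not separate the two groups at this position, and with nitro held in place, the exchange at the other site gives a 1.1-fold higher number from compound 1 to compound 4 (0.06 log units; within the scatter), which does not separate bromo from amino either. Nitro in place of hydrogen on the same carbon gives an at least 2.5-fold lower number from compound 2 to compound 4 (0.39 log units; beyond the scatter), the only step at this carbon shown so far whose floor lies beyond the scatter, whereas the floor of the corresponding methoxy step stays within it. Compound 2 is a limit of the assay and not a number, so this step has a floor and no fixed size: the limit of > 100000 nM in this assay, at which 1 of the 4 values shown sits.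

Going by these compounds, how far hydrogen truly stands from nitro or methoxy on this carbon stays open, as does any ranking of those two substituted compounds against it beyond that floor. Also open, on these data alone, is whether a different group on this carbon, such as a carboxylic acid, a dimethylamino group or a nitrile, would give a number clearly apart from those of compound 3 and compound 4.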